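A few compounds are considered here, and "the series" means these few. Any claim that something is new, unique, unknown or untested is made for them only; others in the source may bear on it.

Compound 1 `COc1cc(-c2cc(/C=C/C(=O)c3ccc(Cl)c(Cl)c3)[nH]n2)cc(OC)c1OC` carries a 3,4-dichlorophenyl on the carbonyl carbon of the enone that links its shared core to the aryl ketone. For the measured compounds named here, in a functional assay on SR cells (Homo sapiens) for inhibition, read by sulforhodamine B assay, with a stated time of 48 h (a lower number here means a stronger inhibitor of growth, a higher number a weaker inhibitor of growth), compound 1 gives 13500 nM, the higher of the two numbers measured so far. The companion in the set is compound 2 `COc1ccc(-c2cc(/C=C/C(=O)c3ccc(N)cc3)[nH]n2)cc1OC`, which differs in more than one place; in this assay compound 2 gives 5310 nM, and the gap between these two values lies beyond the scatter.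

The next member, compound 3 `COc1cc(-c2cc(/C=C/C(=O)c3ccc(F)c(F)c3)[nH]n2)cc(OC)c1OC`, keeps everything of compound 1 apart from one change: 3,4-difluorophenyl in place of 3,4-dichlorophenyl on a carbonyl carbon. Going by the values given here, no measured pair in this small set shows what such a halogen exchange does here, so no direction can be read from the data. The step from compound 1 to compound 3 is expected to be small, a 1.1-fold higher number from compound 1 to compound 3 (0.05 log units; within the scatter), within or close to the scatter in this assay. On that basis compound 3 is estimated at 15000 nM, within a range of 6000 nM to 40000 nM.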

Compound 3, concentration for total growth inhibition: > 100000 nM
Compound 3 gave a limit, no number; the forecaster's own chance of this, stated with the estimate: 5%; middle value at least 6.6-fold (0.82 log units) away from the limit.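

Swapping the halogens on the aryl ketone is not a neutral exchange at this position: 3,4-difluorophenyl in place of 3,4-dichlorophenyl on a carbonyl carbon gives an at least 7.4-fold higher number from compound 1 to compound 3 (0.86 log units; beyond the scatter) in this assay. Compound 3 stands at > 100000 nM, which is a limit of the assay and not a number. The step is therefore open on one side, and its full size cannot be fixed: the limit of > 100000 nM in this assay, at which 1 of the 3 values shown sits.

One exchange on one core cannot show whether the same step would hold with other substituents on the core. From the compounds shown here alone, how a 3,4-dibromophenyl or an unsubstituted phenyl on that carbonyl carbon would stand on the core of compound 1 remains open, so no trend across the halogens can be drawn yet.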